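Swapping Fluoro for Dimethylamino in a Paw-Edema Series

The compounds below may be only part of what the source reports. "The series", "measured", "known", "first", "only" and "open" are said of these compounds alone.

Compound 1, `CN(C)c1ccc(C2CC(c3ccc(Br)cc3)=NN2c2nc3ccc(S(N)(=O)=O)cc3s2)cc1`, gives 14% in a functional assay on the whole organism (strain Wistar) for inhibition, with Rattus norvegicus as the target, read by paw edema, with stated times of 1 h and 5 h, at a dose of 20 mg/kg by the oral route; on this read-out lower numbers stand for less inhibition and higher numbers for more inhibition at the one dose given (going by the name of the read-out).
Compound 2, `NS(=O)(=O)c1ccc2nc(N3N=C(c4ccc(Cl)cc4)CC3c3ccc(Cl)cc3)sc2c1`, gives 14% in this assay.
Compound 3, `NS(=O)(=O)c1ccc2nc(N3N=C(c4ccc(Cl)cc4)CC3c3ccc(F)cc3)sc2c1`, gives 14% in this assay.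

All three compounds share one core and were tested in this assay at a single dose. Compound 3 stands level with compound 1 and compound 2; none of the gaps between them exceeds the usual scatter. Among the measured compounds shown here, the only one-place change measured so far, no change at the digits printed from compound 2 to compound 3 (within the scatter), was fluoro in place of chloro on an aromatic carbon.

Compound 4, `CN(C)c1ccc(C2CC(c3ccc(Cl)cc3)=NN2c2nc3ccc(S(N)(=O)=O)cc3s2)cc1`, has not yet been measured. It differs from compound 3 by dimethylamino in place of fluoro on an aromatic carbon. For the measured compounds named here, no measured step covers this exact change, but compound 1 already carries a dimethylamino group on the same kind of ring and sits at the same level as the others. Because compound 1 with its dimethylamino group gives 14%, the expectation for no change at the digits printed from compound 3 to compound 4 (within the scatter) is no change beyond the scatter. Compound 4 is therefore estimated at 14% in this assay, expected to fall between 5% and 25%.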

Compound 4, a percentage reported as inhibition, in the whole organism at one dose (the size of the read-out at that dose, not a potency): 14%
Beside the measured number, compound 4's estimate shows no gap at the digits printed; the range from low to high includes it.
By their numbers in this assay, from the lowest: compounds 1, 2, 3 and 4 (each within the scatter of the next).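

In this assay, the site that carried only a halogen in compound 2 and compound 3 also accepts dimethylamino, a group of three heavy atoms in place of one: the fluoro swap gives no change at the digits printed from compound 3 to compound 4 (within the scatter), and the chloro swap gives no change at the digits printed from compound 2 to compound 4 (within the scatter). With dimethylamino held in place, changing the halogen on the other aromatic ring gives no change at the digits printed from compound 1 to compound 4 (within the scatter), so neither site has yet moved the reading. No available evidence accounts for these level readings.

Going by these compounds, it remains open whether any group at the dimethylamino site, such as a carboxylic acid or a longer chain, would shift the reading beyond the scatter. A reading at a single dose also leaves open how these compounds would compare across other doses.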